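From 2-chlorophenyl to 4-methylbenzyl on the amide nitrogen

A few compounds are considered here, and "the series" means these few. Any claim that something is new, unique, unknown or untested is made for them only; others in the source may bear on it.

Compound 1 (`CCOC(=O)[C@]1(C(=O)Nc2ccccc2Cl)C[C@@H]1c1cc(OC)c(OC)c(OC)c1`): 34700 nM
Compound 2 (`CCOC(=O)C1(C(=O)NCc2ccc(C)cc2)CC1c1cc(OC)c(OC)c(OC)c1`): > 100000 nM; 37900 nM (2 entries)

Going by the values given here, in a functional assay on QGY cells (Homo sapiens) for cytotoxicity, read by MTT assay, with a stated time of 48 h (on this read-out lower numbers stand for stronger inhibition and higher numbers for weaker inhibition), compound 1 holds the only single number, 34700 nM. Compound 2 has no single number, and its entries are shown in > 100000 nM; 37900 nM (2 entries). One of the entries of compound 2 is a limit of the assay. Compound 3 (`CCOC(=O)[C@]1(C(=O)NCc2ccc(C)cc2)C[C@@H]1c1cc(OC)c(OC)c(OC)c1`) carries 4-methylbenzyl in place of 2-chlorophenyl on an amide-type nitrogen. Judging from compound 2 (the several entries of compound 2 in this assay, > 100000 nM; 37900 nM (2 entries)), a small weakening in this assay is expected, hardly beyond the scatter. The expected step is a 1.6-fold higher number from compound 1 to compound 3 (0.20 log units; within the scatter). Compound 3 is estimated at 55000 nM, with an expected range of 22000 nM to 130000 nM.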

Compound 3, half-maximal inhibitory concentration: > 100000 nM
Compound 3: a limit, no number; the forecaster's own chance of this, stated with the estimate: 35%; middle value at least 1.8-fold (0.25 log units) away from the limit.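

With 4-methylbenzyl in place of 2-chlorophenyl on an amide-type nitrogen, this assay shows an at least 2.8-fold higher number from compound 1 to compound 3 (0.45 log units; beyond the scatter). Compound 3 gives > 100000 nM, which is a limit of the assay and not a number. This position therefore does not tolerate the change without loss in this assay, which compound 2 alone could not establish because its readings are split: the several entries of compound 2 in this assay, > 100000 nM; 37900 nM (2 entries)

Going by these compounds, the true size of the step remains open. So does whether it follows from the change of ring substituent or from the added carbon, which a benzyl or 2-chlorobenzyl group on the same nitrogen would help separate.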